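A Saturated Amine Ring Replaces the Pyridylpropyl Chain

The source may hold more compounds than are shown below. What is called first, only, known or untested is meant among the compounds shown, and "the series" means these compounds.

Compound 3 `CC(=O)SCC(=O)c1ccc(NS(=O)(=O)c2ccc(OCCCc3ccccn3)cc2)nc1` carries a 3-(pyridin-2-yl)propyl group on an oxygen on an aromatic ring, but in a functional assay on HCT-116 cells (Homo sapiens) for cytotoxicity (on this read-out lower numbers stand for an effect already at smaller amounts and higher numbers for an effect only at larger amounts of compound), compound 3 gives "not determined" (no result reported), so its own standing cannot be placed on the scale. Its neighbours give the only footing. Among the measured compounds shown here, compound 1 `CC(=O)SCC(=O)c1ccc(NS(=O)(=O)c2ccc(OCCCN3CCCCC3)cc2)nc1` gives 1000 nM in this assay, and compound 2 `CC(=O)SCC(=O)c1ccc(NS(=O)(=O)c2ccc(OCc3ccccn3)cc2)nc1` gives 420 nM in this assay; the change a 2.4-fold lower number from compound 1 to compound 2 (0.38 log units; beyond the scatter) is the single measured step, and it is modest. Compound 4 `CC(=O)SCC(=O)c1ccc(NS(=O)(=O)c2ccc(OC3CCCN(C)C3)cc2)nc1` differs from compound 3 by the change (1-methylpiperidin-3-yl in place of 3-(pyridin-2-yl)propyl on an oxygen on an aromatic ring), that is, a 1-methylpiperidin-3-yl group in place of the 3-(pyridin-2-yl)propyl group on the oxygen. For the measured compounds named here, no measured step reproduces this exact change, and compound 3 itself has no value to step from. Compound 1, which also bears a saturated nitrogen ring, gives 1000 nM in this assay, so compound 4 is expected to fall in a similar region, with an estimate of 800 nM ranging from 250 nM to 2500 nM.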

Compound 4, half-maximal effective concentration: 3700 nM
For compound 4 the middle estimate is 4.6-fold (0.67 log units) below the measured one, and the stated range ends below it.
By their numbers in this assay, from the lowest: compound 2; then compound 1; then compound 4.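

In this assay the 1-methylpiperidin-3-yl group on the oxygen gives a 3.7-fold higher number from compound 1 to compound 4 (0.57 log units; beyond the scatter) and so shows that a saturated nitrogen ring at this position does not by itself hold the number at the level seen with the 3-(piperidin-1-yl)propyl group; the form of the whole group on the oxygen matters too. Set against the (pyridin-2-yl)methyl group, the same entry gives the larger 8.8-fold higher number from compound 2 to compound 4 (0.94 log units; beyond the scatter) and leaves compound 4 with the highest number of the three compounds that have values. Steps to or from compound 3 cannot be read, as it has no value.

Still open, on these data alone, is how a morpholine ring or an open-chain dimethylamino group on the same oxygen would stand against compound 4. Nothing measured here gives a reason for these differences.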